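Replacing piperazin-1-yl with 1,3-thiazol-2-yl in compound 3

A few compounds are considered here, and "the series" means these few. Any claim that something is new, unique, unknown or untested is made for them only; others in the source may bear on it.

- Compound 1 `O=S(=O)(Nc1nccs1)c1ccc2c(c1)OCC[C@@H]2c1ccc(C(F)(F)F)cc1-c1ccc(F)cc1`: 39000 nM
- Compound 2 `Cc1nc(-c2cc(C(F)(F)F)ccc2[C@H]2CCOc3cc(S(=O)(=O)Nc4nccs4)ccc32)co1`: 61000 nM
- Compound 3 `O=S(=O)(Nc1nccs1)c1ccc2c(c1)OCC[C@@H]2c1ccc(C(F)(F)F)cc1N1CCNCC1`: 288000 nM

These three compounds were measured in a physicochemical assay for solubility; a lower number here means a less soluble compound, a higher number a more soluble compound. Compound 3 stands highest of the three at 288000 nM, and its gap to each of the others lies beyond the scatter. Compound 4 `O=S(=O)(Nc1nccs1)c1ccc2c(c1)OCC[C@@H]2c1ccc(C(F)(F)F)cc1-c1nccs1` differs from it by one change: 1,3-thiazol-2-yl in place of piperazin-1-yl on an aromatic carbon.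

Two measured steps put piperazin-1-yl in place of an aromatic ring: a 7.4-fold higher number from compound 1 to compound 3 (0.87 log units; beyond the scatter) and a 4.7-fold higher number from compound 2 to compound 3 (0.67 log units; beyond the scatter). Both are modest. The third step, which swaps one aromatic ring for another, is a 1.6-fold higher number from compound 1 to compound 2 (0.19 log units; within the scatter). The new group is also an aromatic ring, so a modest fall in this assay is expected, beyond the scatter, which would bring the number back near the other two. The expected step is a 5.8-fold lower number from compound 3 to compound 4 (0.76 log units; beyond the scatter). The estimate for compound 4 is 50000 nM, with an expected range of 22000 nM to 110000 nM.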

Compound 4, solubility: 15000 nM
The estimate for compound 4 lay 3.3-fold (0.52 log units) above the measured number; the whole stated range lies above it.
By their numbers in this assay, from the lowest: compound 4; then compounds 1 and 2 (each within the scatter of the next); then compound 3.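

In this assay, 1,3-thiazol-2-yl in place of piperazin-1-yl gives a large fall, a 19-fold lower number from compound 3 to compound 4 (1.28 log units; beyond the scatter), and this aromatic ring also ends up apart from the other two, with a 4.1-fold lower number from compound 2 to compound 4 (0.61 log units; beyond the scatter) and a 2.6-fold lower number from compound 1 to compound 4 (0.41 log units; beyond the scatter). The earlier compounds shown here showed two different aromatic rings at this position staying within the scatter of each other, but compound 4 shows that not every aromatic ring here gives that level, so the choice of ring can matter on its own. Nothing available explains why this ring gives the lowest number of the four.

On these data alone, it remains open whether the high number of compound 3 needs the second nitrogen of piperazine, which a morpholine ring, with oxygen in its place, would test. A pyridine ring or an open-chain amine at this position would show how far the pattern extends.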